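From amino to hydroxy: one swap on compound 3

The compounds below may be only part of what the source reports. "The series", "measured", "known", "first", "only" and "open" are said of these compounds alone.

Compound 1 `O=c1[nH]c(-c2ccccc2O)nc2c1cnn2-c1ccccc1`: 500 nM
Compound 2 `CC(C)Oc1ccccc1-c1nc2c(cnn2-c2ccc(Br)cc2)c(=O)[nH]1`: 280 nM
Compound 3 `Nc1ccccc1NCc1nc2c(cnn2-c2ccccc2)c(=O)[nH]1`: 6800 nM

All three compounds were tested in a functional assay on corpus cavernosum (Rattus norvegicus) for activation; a higher number here means that more compound is needed for the effect, a lower number that less compound is needed. Compound 3, at 6800 nM, has the highest of the three numbers, so it needs the most compound for the effect. Its nearest neighbour is compound 1 at 500 nM, and furthest away lies compound 2 at 280 nM. Both gaps are beyond the usual scatter.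

The next compound to be measured is compound 4 `O=c1[nH]c(CNc2ccccc2O)nc2c1cnn2-c1ccccc1`. It has hydroxy in place of amino on an aromatic carbon, ortho to a large group: hydroxy in place of amino on an aromatic carbon. Put another way, 2-aminophenyl becomes 2-hydroxyphenyl.

Among the compounds with values here, no two measured compounds differ in only one place, so the effect of a single change has not been seen directly here. Compound 4 differs from compound 3 only by this swap, so the expectation starts from 6800 nM. Compound 1 also carries a 2-hydroxyphenyl and gives 500 nM, which tilts the expectation gently towards a lower number, although the rest of its structure is different. The expected change is modest, estimated as a 2.3-fold lower number from compound 3 to compound 4 (0.36 log units; beyond the scatter). Compound 4 is estimated at 3000 nM, with an expected range of 800 nM to 11000 nM.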

Compound 4, half-maximal effective concentration: 250 nM
The estimate for compound 4 lay 12-fold (1.08 log units) above the measured number; the measured number lies below the stated range.
By their numbers in this assay, from the lowest: compounds 4, 2 and 1 (each within the scatter of the next); then compound 3.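

Within the data shown here, this is the first single change that can be read directly in this set: in this assay, putting hydroxy in place of amino on an aromatic carbon, ortho to a large group, gives a 27-fold lower number from compound 3 to compound 4 (1.43 log units; beyond the scatter). The two structures differ in nothing else. One nitrogen leaves and one oxygen enters, and the counts stay matched, with one hydrogen-bond donor, one hydrogen-bond acceptor and no net charge on each side, so exchanging this one atom at this position is enough to produce a large step. No measured property is available to explain the size of this step.

From the compounds shown here alone, whether the lower number depends on hydroxy itself remains open, since a methoxy group, a fluorine atom or a carboxylic acid at the same place would be needed to test it, and the amino and hydroxy pair alone cannot separate these possibilities. Going by these compounds, it is also open whether the same swap would give a step of similar size on a different core, or with a longer chain joining the 2-hydroxyphenyl group to the core.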